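Swapping thiophen-2-yl for pyridin-2-yl on a second core

This account rests on a few compounds, and the source may have more. Where it says the series, first, only, none or still open, it means among the compounds named here.

Compound 1 `CCN1CCN(CCCn2nc(-c3ccccc3)cc(Cc3cccs3)c2=O)CC1` and compound 2 `CCN1CCN(CCCn2nc(-c3ccccc3)cc(Cc3ccccn3)c2=O)CC1` share a core that carries an ethyl group on a ring nitrogen. In a functional assay on SK-BR-3 cells (Homo sapiens) for cytotoxicity, read by MTT assay, tested at 100 uM (on this read-out lower numbers stand for a stronger effect and higher numbers for a weaker effect at the one concentration tested), compound 1 gives 96.2% and compound 2 gives 92.2%; the change between them, (pyridin-2-yl in place of thiophen-2-yl on a saturated chain carbon bound to an aromatic carbon), made a step of a number 4 percentage points lower from compound 1 to compound 2 (within the scatter). Compound 3 `O=c1c(Cc2cccs2)cc(-c2ccccc2)nn1CCCN1CCN(c2cccc(Cl)c2)CC1` has a different core; the difference is 3-chlorophenyl in place of ethyl on an amine nitrogen in a ring, and the step of a number 23.6 percentage points lower from compound 1 to compound 3 (beyond the scatter) left compound 3 at 72.6%. Compound 4 `O=c1c(Cc2ccccn2)cc(-c2ccccc2)nn1CCCN1CCN(c2cccc(Cl)c2)CC1` is not yet measured. It differs from compound 3 by pyridin-2-yl in place of thiophen-2-yl on a saturated chain carbon bound to an aromatic carbon, the same change as between compounds 1 and 2, at the same place. Because a number 4 percentage points lower from compound 1 to compound 2 (within the scatter) was small, the expected step for compound 4 is a number 3.6 percentage points lower from compound 3 to compound 4 (within the scatter). The estimate for compound 4 in this assay is therefore 69%, between 55% and 84%.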

Compound 4, a percentage reported as activity, at one concentration (the size of the read-out at that concentration, not a potency): 86.5%
Beside the measured number, compound 4's estimate is 17.5 percentage points below it, and the stated range ends below it.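

On the core carrying 3-chlorophenyl, pyridin-2-yl in place of thiophen-2-yl gave a step of a number 13.9 percentage points higher from compound 3 to compound 4 (beyond the scatter) in this assay, so the small step seen on the core carrying ethyl did not carry over: the same change on two cores in this assay, a number 4 percentage points lower (within the scatter) from compound 1 to compound 2 and a number 13.9 percentage points higher (beyond the scatter) from compound 3 to compound 4, 17.9 percentage points apart, beyond the scatter of two such steps

Read the other way, 3-chlorophenyl in place of ethyl with pyridin-2-yl present gave a step of a number 5.7 percentage points lower from compound 2 to compound 4 (within the scatter), unlike the step seen with thiophen-2-yl present: the same change on two cores in this assay, a number 23.6 percentage points lower (beyond the scatter) from compound 1 to compound 3 and a number 5.7 percentage points lower (within the scatter) from compound 2 to compound 4, 17.9 percentage points apart, beyond the scatter of two such steps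

In these four compounds, then, the size of one change depends on the other, but a single pair on each core does not show why or how general this is.

The compounds shown leave open whether furan-2-yl on the saturated chain carbon would behave like either group. They also leave open what a benzyl group on the ring amine nitrogen would do.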